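The source may report more compounds than this note shows. Statements on the series, on what has been measured and on what is new or still open speak of the compounds shown alone.

In an ADME assay on 184B5 cells (Homo sapiens) for cytotoxicity, read by sulforhodamine B assay, with a stated time of 48 h (on this read-out higher numbers stand for weaker inhibition of growth and lower numbers for stronger inhibition of growth), three compounds have been measured so far. Compound 1 `Cc1ccc2nc(/N=C3\C(=O)N(CN4CCCCC4)c4ccccc43)sc2c1` gives 34900 nM in this assay. Compound 2 `O=C1C(=O)N(CN(c2ccccc2)c2ccccc2)c2cccc(Cl)c21` gives 96800 nM in this assay, and compound 3 `CCN(CC)CN1C(=O)C(=O)c2c(Br)cccc21` gives 172000 nM in this assay. Among these numbers compound 2 stands second highest: its value sits within the scatter of that of compound 3, so nothing separates those two, while compound 1 shows a lower number beyond the scatter, which on this read-out means stronger inhibition of growth than compound 2.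

Compound 4 `O=C1C(=O)N(CN(c2ccccc2)c2ccccc2)c2cccc(Br)c21` has not been measured yet. It differs from compound 2 in a single place: bromo in place of chloro on an aromatic carbon. Among the measured compounds shown here, no measured pair shows this change, so no step can be read from the data. An exchange of one halogen for another on an aromatic carbon is expected to move the number little, with no step beyond the scatter in either direction. The estimated step of a 1.1-fold lower number from compound 2 to compound 4 (0.03 log units; within the scatter) is expected to be small. Compound 4 is therefore expected to give about 90000 nM in this assay, within a range from 40000 nM to 200000 nM.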

Compound 4, concentration for 50% growth inhibition: 98500 nM
Compound 4: middle estimate off by 1.1-fold (0.04 log units), on the low side, and the stated range covers the measured number.
By their numbers in this assay, from the lowest: compound 1; then compounds 2, 4 and 3 (each within the scatter of the next).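

Among the compounds shown here, this pair gives the first reading of a single exchange in the set: in this assay, bromo in place of chloro on this aromatic carbon amounts to a 1.0-fold higher number from compound 2 to compound 4 (0.01 log units; within the scatter). At this position, with the rest of the molecule unchanged, the two halogens cannot be told apart. No measurement shown here offers a reason for this.

On these data alone, the pair covers only these two halogens, so it remains open whether a clearly different group on the same carbon, such as a methoxy group, an amine or a carboxylic acid, would leave the number just as unchanged. As far as these compounds go, compounds 1 and 3 differ from this pair in more than one place, so no steps can be read to them, and whether the exchange would give the same result on their cores also remains open.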